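Series notes on a repeated fluoro replacement

The compounds below may be only part of what the source reports. "The series", "measured", "known", "first", "only" and "open" are said of these compounds alone.

Compound 1 `N#Cc1ccc(F)c([S+]([O-])c2nc(-c3cnn4ccc(Br)cc34)cs2)c1` and compound 2 `N#Cc1ccc(F)c(S(=O)(=O)c2nc(-c3cnn4ccc(Br)cc34)cs2)c1` share most of their structure; the difference between their two cores is not broken down here. In an assay on isolated protein for inhibition of phosphatidylinositol 4,5-bisphosphate 3-kinase catalytic subunit beta isoform (Homo sapiens) (a higher number here means a weaker inhibitor, a lower number a stronger inhibitor), compound 1 gives only a limit, > 1000 nM. In this assay compound 2 likewise gives only a limit, > 1000 nM. Compound 3 `CN(C)CCN(C)c1ccc(C#N)cc1[S+]([O-])c1nc(-c2cnn3ccc(Br)cc23)cs1` carries the change (2-(dimethylamino)ethyl)(methyl)amino in place of fluoro on an aromatic carbon relative to compound 1, and in this assay compound 3 gives 4340 nM. The step that the limit leaves unreadable from compound 1 to compound 3 cannot be sized because of the limit of > 1000 nM in this assay, at which 2 of the 3 values shown sit.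

Compound 4 `CN(C)CCN(C)c1ccc(C#N)cc1S(=O)(=O)c1nc(-c2cnn3ccc(Br)cc23)cs1` stands to compound 2 as compound 3 stands to compound 1: the change ((2-(dimethylamino)ethyl)(methyl)amino in place of fluoro on an aromatic carbon), the same kind of change at the same described place. Going by the values given here, the step from compound 1 to compound 3 is not readable, so the expectation for compound 4 rests on compound 3 alone, whose value 4340 nM is the only number measured in this assay. Compound 4 is therefore expected to sit near compound 3, with the step that the limit leaves unreadable from compound 2 to compound 4 taken as an estimate only. The estimate for compound 4 in this assay is 5000 nM, within 1500 nM to 15000 nM.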

Compound 4, half-maximal inhibitory concentration: 3560 nM
Compound 4: the middle estimate sits 1.4-fold (0.15 log units) above what was measured, and the stated range covers the measured number.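

No step can be read from compound 2 to compound 4 in this assay, nor from compound 1 to compound 3, because compound 1 and compound 2 each give only a limit: the limit of > 1000 nM in this assay, at which 2 of the 4 values shown sit.

The compounds shown leave open how large the effect of (2-(dimethylamino)ethyl)(methyl)amino in place of fluoro is in either pair.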